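This account rests on a few compounds, and the source may have more. Where it says the series, first, only, none or still open, it means among the compounds named here.

Measured so far in a functional assay on MDA-MB-231 cells (Homo sapiens) for cytotoxicity, read by MTT assay, with a stated time of 72 h; a lower number here means a stronger inhibitor, a higher number a weaker inhibitor:

Compound 1 `COc1cc2c(Oc3ccc(NC(=O)c4nn(-c5ccc(Br)cc5)c(=O)c5ccccc45)cc3F)ccnc2cc1OCCCN1CCN(C)CC1`: compound 1 gives 1370 nM
Compound 2 `COc1cc2c(Oc3ccc(NC(=O)c4nn(-c5ccc([N+](=O)[O-])cc5)c(=O)c5ccccc45)cc3F)ccnc2cc1OCCCN1CCN(C)CC1`: compound 2 gives 3490 nM
Compound 3 `COc1cc2c(Oc3ccc(NC(=O)c4nn(-c5ccc(Br)cc5)c(=O)c5ccccc45)cc3F)ccnc2cc1OCCCN1CCCCC1`: compound 3 gives 1130 nM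

Compound 4 `COc1cc2c(Oc3ccc(NC(=O)c4nn(-c5ccc([N+](=O)[O-])cc5)c(=O)c5ccccc45)cc3F)ccnc2cc1OCCCN1CCCCC1` has not yet been measured.

The three measured compounds share one core, which is varied at two places. Compound 1 and compound 3 differ at the chain end: piperidin-1-yl in place of 4-methylpiperazin-1-yl on a saturated chain carbon, three bonds along the chain from an oxygen on an aromatic ring. In this assay that exchange gives a 1.2-fold lower number from compound 1 to compound 3 (0.08 log units; within the scatter), so the two chain ends cannot be told apart here. Compound 1 and compound 2 differ at the aryl substituent: nitro in place of bromo on an aromatic carbon. This step reads a 2.5-fold higher number from compound 1 to compound 2 (0.41 log units; beyond the scatter), a modest weakening.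

Compound 4 carries both changes relative to compound 1: it is compound 3 with the same aryl exchange, (nitro in place of bromo on an aromatic carbon). The place of the exchange is the same in both pairs, word for word, so this is the same change made on the core of compound 3 instead of the core of compound 1. Among the measured compounds shown here, only the one measured pair speaks to it, so the expectation rests on that pair alone.

For the measured compounds named here, compound 4 is expected to weaken by about as much as compound 2 did relative to compound 1, that is an estimated 2.5-fold higher number from compound 3 to compound 4 (0.39 log units; beyond the scatter), because the step of a 2.5-fold higher number from compound 1 to compound 2 (0.41 log units; beyond the scatter) is the only measurement of this change. With compound 3 at 1130 nM as the starting point, compound 4 is estimated at 2800 nM, with a likely range from 1400 nM to 5600 nM.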

Compound 4, half-maximal inhibitory concentration: 2620 nM
Beside the measured number, compound 4's estimate is 1.1-fold (0.03 log units) above it; low and high end bracket the measured number.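

In this assay the exchange of bromo for nitro carries from the core of compound 1 to the core of compound 3, with a 2.3-fold higher number from compound 3 to compound 4 (0.37 log units; beyond the scatter) on the second core, and the two steps agree: the same change on two cores in this assay, a 2.5-fold higher number (0.41 log units; beyond the scatter) from compound 1 to compound 2 and a 2.3-fold higher number (0.37 log units; beyond the scatter) from compound 3 to compound 4, 1.1-fold (0.04 log units) apart, within the scatter of two such steps.
The exchange of 4-methylpiperazin-1-yl for piperidin-1-yl stays within the scatter with nitro on the aryl ring as well, at a 1.3-fold lower number from compound 2 to compound 4 (0.12 log units; within the scatter) in this pair, and it also agrees with the step measured with bromo: the same change on two cores in this assay, a 1.2-fold lower number (0.08 log units; within the scatter) from compound 1 to compound 3 and a 1.3-fold lower number (0.12 log units; within the scatter) from compound 2 to compound 4, 1.1-fold (0.04 log units) apart, within the scatter of two such steps.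
Across these four compounds each change therefore behaves the same on both cores, but this rests on a single pair of cores per change in a single cell assay, and it shows neither why nitro gives the higher number nor that the agreement extends to other groups.

Going by these compounds, whether other groups at the same aryl position, such as chloro, methoxy or an amine, would also transfer from core to core remains open. On these data alone, it is also open whether a morpholin-4-yl group or a shorter chain at the other end would separate from the two chain ends, which cannot be told apart here, and whether such a change would leave the aryl step intact.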